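Replacing a Bromophenyl Arm with a Chlorohydroxyphenyl Arm

This account rests on a few compounds, and the source may have more. Where it says the series, first, only, none or still open, it means among the compounds named here.

Three compounds share one core and are compared in a functional assay on SW-620 cells (Homo sapiens) for cytotoxicity, read by MTT assay, with a stated time of 72 h; a lower number here means a stronger inhibitor, a higher number a weaker inhibitor. Compound 1 `COc1cccc(/C=C2\CCC/C(=C\c3ccc(Br)cc3)C2=O)c1OC` gives 11100 nM. Compound 2 `COc1cccc(/C=C2\CCC/C(=C\c3ccc(Cl)cc3Cl)C2=O)c1OC` gives 16300 nM. Compound 3 `COc1ccc(/C=C2\CCC/C(=C\c3ccc(Br)cc3)C2=O)cc1OC` gives 5200 nM, the lowest of the three numbers; its gap to compound 1 and its gap to compound 2 both lie beyond the scatter, so compound 3 counts as the strongest inhibitor among the measured set.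

Compound 4 `COc1ccc(/C=C2\CCC/C(=C\c3ccc(O)c(Cl)c3)C2=O)cc1OC` has not yet been measured. It differs from compound 3 in one place: 3-chloro-4-hydroxyphenyl in place of 4-bromophenyl on a double-bonded chain carbon bound to a double-bonded ring carbon.

Within the data shown here, only one measured step touches the same place. It is a 1.5-fold higher number from compound 1 to compound 2 (0.17 log units; within the scatter). That single step, which swapped one halogenated ring for another on the same chain carbon, moved the number hardly at all. Among the measured compounds shown here, the new ring on compound 4 carries a hydroxyl group, and no measured pair here shows what a hydroxyl group does at that place, so that part of the change is untested.

For the measured compounds named here, on the one step that bears on it, the expectation is a move of a 1.2-fold higher number from compound 3 to compound 4 (0.06 log units; within the scatter), that is, no step beyond the scatter. Compound 4 is therefore estimated to give 6000 nM, with a likely range from 2500 nM to 15000 nM.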

Compound 4, half-maximal inhibitory concentration: 7100 nM
Estimate against measurement, compound 4: 1.2-fold (0.07 log units) below; the range from low to high includes it.
By their numbers in this assay, from the lowest: compounds 3, 4, 1 and 2 (each within the scatter of the next, the first and the last beyond it).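

In this assay, the change at this place, on a double-bonded chain carbon bound to a double-bonded ring carbon, gives (a 1.4-fold higher number from compound 3 to compound 4 (0.14 log units; within the scatter)), so compound 3 and compound 4 cannot be told apart. The earlier step at this place (a 1.5-fold higher number from compound 1 to compound 2 (0.17 log units; within the scatter)) only exchanged one halogen-bearing ring for another, whereas this one replaces a group with no hydrogen-bond donor or acceptor by one that has both, and the result still stays within the scatter. Among these compounds, this is the first sign that the 4-bromophenyl group can give way to a ring with a hydroxyl group without a readable change in this assay, although nothing available here explains that result.

The chlorine and the hydroxyl group arrive together in the 3-chloro-4-hydroxyphenyl group, so the compounds shown cannot separate what each contributes, and a ring carrying only one of the two would be needed to do that. On these data alone, it also remains open whether this place would accept quite different groups on the ring, such as an amine, a carboxylic acid or a longer chain.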